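Changing the group on the aromatic nitrogen

The source may report more compounds than this note shows. Statements on the series, on what has been measured and on what is new or still open speak of the compounds shown alone.

Compound 1 `Oc1cc(C(F)(F)F)ccc1-c1nc(-c2ccccc2O)n(-c2ccc(Cl)cc2)n1` and compound 2 `Oc1cc(C(F)(F)F)ccc1-c1nc(-c2ccccc2O)n(-c2ccc(OC(F)(F)F)cc2)n1` share one core and differ only in the group attached to the aromatic nitrogen. In a functional assay on PC-12 cells (Rattus norvegicus) for cytotoxicity, read by MTT assay, with stated times of 2 h and 24 h, tested at 1 uM (a higher number here means a stronger effect of the compound at the concentration tested, a lower number a weaker effect), compound 1 gives 68%, while compound 2 gives 65.5%, the lower of the two numbers, although the step of a number 2.5 percentage points lower from compound 1 to compound 2 (within the scatter) stays within the scatter. Compound 3 `Cc1ccc(-n2nc(-c3ccc(C(F)(F)F)cc3O)nc2-c2ccccc2O)c(C)c1` differs from compound 2 by 2,4-dimethylphenyl in place of 4-(trifluoromethoxy)phenyl on an aromatic nitrogen. Among the compounds with values here, the only measured step at this place, a number 2.5 percentage points lower from compound 1 to compound 2 (within the scatter), was within the scatter, so no step beyond the scatter is expected here either. Compound 3 is therefore expected to give 66%, in a range from 50% to 80%. The expected step is a number 0.5 percentage points higher from compound 2 to compound 3 (within the scatter).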

Compound 3, a percentage reported as activity, at one concentration (the size of the read-out at that concentration, not a potency): 73.7%
Estimate against measurement, compound 3: 7.7 percentage points below, within the range that was stated.
By their numbers in this assay, from the lowest: compounds 2, 1 and 3 (each within the scatter of the next).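

In this assay the change to 2,4-dimethylphenyl, which carries only carbon in place of the oxygen and fluorine of 4-(trifluoromethoxy)phenyl, gives a number 8.2 percentage points higher from compound 2 to compound 3 (within the scatter) and, set against 4-chlorophenyl, gives a number 5.7 percentage points higher from compound 1 to compound 3 (within the scatter) on this aromatic nitrogen. The read-out therefore does not separate these three substituted phenyl groups, even though the newest one has no halogen. Nothing measured here bears on this result.

As far as these compounds go, it remains open whether a group other than a substituted phenyl, such as a benzyl or a short alkyl chain, would move the number beyond the scatter. The same holds for a phenyl bearing an amine or a carboxylic acid.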